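Bromo in place of methyl on an aromatic carbon

This account rests on a few compounds, and the source may have more. Where it says the series, first, only, none or still open, it means among the compounds named here.

Values in a functional assay on HGC-27 cells (Homo sapiens) for cytotoxicity, read by MTT assay, with a stated time of 72 h (a lower number here means a stronger inhibitor, a higher number a weaker inhibitor), so far:
- compound 1 `CC(=C\c1ccccc1)/C=C1\CCC=CC1=O` gives 5200 nM
- compound 2 `O=C1C=CCC/C1=C\C(Br)=C\c1ccccc1` gives > 10000 nM as a limit of the assay and not a number
- compound 3 `Cc1ccc(/C=C/C=C2\CCC=CC2=O)cc1` gives 8100 nM

Compound 1 (5200 nM) and compound 3 (8100 nM) lie within the scatter of each other. The unmeasured compound 4 `O=C1C=CCC/C1=C\C=C\c1ccc(Br)cc1` differs from compound 3 in one place: bromo in place of methyl on an aromatic carbon, with bromo in place of methyl on an aromatic carbon, para to a large group.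

Going by the values given here, the only measured step with the same exchange stands on a chain carbon instead: an at least 1.9-fold higher number from compound 1 to compound 2 (0.28 log units; that floor lies within the scatter). The end of that step is the limit of > 10000 nM in this assay, at which 1 of the 3 values shown sits, so it gives a floor and no true size. No exchange on the aromatic carbon has been measured. From compound 3 at 8100 nM no change beyond the scatter is expected in this assay, in either direction.

The estimate for compound 4 is 9000 nM, with an expected range from 4000 nM to 20000 nM. This estimate means a 1.1-fold higher number from compound 3 to compound 4 (0.05 log units; within the scatter) as the expected step.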

Compound 4, half-maximal inhibitory concentration: 4500 nM
Beside the measured number, compound 4's estimate is 2.0-fold (0.30 log units) above it; the measured number falls inside the stated range.
By their numbers in this assay, from the lowest: compounds 4, 1 and 3 (each within the scatter of the next). At a limit, above all of these: compound 2.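

In this assay there is a 1.8-fold lower number from compound 3 to compound 4 (0.26 log units; within the scatter) for bromo in place of methyl on an aromatic carbon, para to a large group, the first measured size for this exchange at this place. The step stays within the scatter, so this read-out does not separate bromo from methyl here, and compound 3 and compound 4 belong to one band. The same exchange on the chain carbon, ending in compound 2, is cut off by a limit of the assay and gives only a floor, so the two places cannot be compared in size: the limit of > 10000 nM in this assay, at which 1 of the 4 values shown sits.

As far as these compounds go, whether an amine, a carboxylic acid or a methoxy group on this aromatic carbon would move the number beyond the scatter stays open. From the compounds shown here alone, the true value of compound 2 also stays open.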